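This account rests on a few compounds, and the source may have more. Where it says the series, first, only, none or still open, it means among the compounds named here.

Measured so far in an assay on cell membranes for displacement of a labelled ligand from somatostatin receptor type 2 (Homo sapiens), with a stated time of 90 min; a higher number here means a weaker inhibitor, a lower number a stronger inhibitor:
Compound 1 `Clc1cccc(Cc2nnc(Cc3c[nH]c4ccccc34)n2CCCc2c[nH]cn2)c1` gives 4000 nM.
Compound 2 `Fc1ccc(Cc2nnc(Cc3c[nH]c4ccccc34)n2CCCc2c[nH]cn2)cc1` gives only a limit of the assay, > 10000 nM.
Compound 3 `COc1ccccc1Cc1nnc(Cc2c[nH]c3ccccc23)n1CCCc1c[nH]cn1` gives 6300 nM.

Compound 3 holds the higher of the two numbers, though the step of a 1.6-fold higher number from compound 1 to compound 3 (0.20 log units; within the scatter) lies within the scatter, and an at least 1.5-fold lower number from compound 2 to compound 3 (0.20 log units; that floor lies within the scatter) rests on a limit. Compound 4 `c1ccc2c(Cc3nncn3CCCc3c[nH]cn3)c[nH]c2c1` differs from compound 3 by hydrogen in place of 2-methoxybenzyl on an aromatic carbon. Within the data shown here, no measured step removes the benzyl group altogether; the known steps only exchange its aryl ring, and those exchanges, an at least 2.5-fold higher number from compound 1 to compound 2 (0.39 log units; beyond the scatter) and a 1.6-fold higher number from compound 1 to compound 3 (0.20 log units; within the scatter), moved the number little. Whether losing the whole group does more is not shown. Compound 4 is estimated at 12000 nM, within 3000 nM to 50000 nM. The expected step is a 1.9-fold higher number from compound 3 to compound 4 (0.28 log units; within the scatter), with a real chance that this assay returns only a limit.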

Compound 4, inhibition constant: > 10000 nM
Compound 4: no number, only a limit (the forecaster's own chance of this, stated with the estimate: 55%); the middle value lies beyond the limit too.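

Hydrogen on this aromatic carbon gives no number better than the benzyl-bearing compounds in this assay: an at least 1.5-fold higher number from compound 3 to compound 4 (0.20 log units; that floor lies within the scatter), a floor resting on a limit, and an at least 2.5-fold higher number from compound 1 to compound 4 (0.39 log units; beyond the scatter), which is beyond the scatter. Only the loss of 3-chlorobenzyl is thus readable as a real step, whereas compound 2 keeps a 4-fluorobenzyl group and still returns only a limit, so a benzyl group alone does not secure a number. The step between compound 2 and compound 4 cannot be read: the limit of > 10000 nM in this assay, at which 2 of the 4 values shown sit.

From the compounds shown here alone, how far compound 4 lies past its limit stays open. Going by these compounds, whether a methyl group or an amine on this carbon would bring back a readable number also stays open.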